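Exchanging an Isobutyl Group for a Pentan-3-yloxy Group

The compounds below may be only part of what the source reports. "The series", "measured", "known", "first", "only" and "open" are said of these compounds alone.

Three compounds were measured in an assay on membranes from HEK293 cells for displacement of a labelled ligand from adenosine receptor A2b (Homo sapiens), read by scintillation counting, with a stated time of 30 min, tested at 1 uM; on this read-out higher numbers stand for more inhibition at the one concentration tested (going by the name of the read-out) and lower numbers for less inhibition. Compound 1 `COC(=O)C1=C(C)NC(=O)NC1c1ccoc1` gives 42%, compound 2 `COC(=O)C1=C(C)NC(=S)NC1c1ccsc1` gives 38%, and compound 3 `CC1=C(C(=O)CC(C)C)C(c2cccs2)NC(=O)N1` gives 43%. Compound 3 thus shows the highest of the three numbers, yet compound 1 and compound 2 both lie within the usual scatter of it, so no order among them can be read. Compound 4 `CCC(CC)OC(=O)C1=C(C)NC(=O)NC1c1cccs1` has not yet been measured. It differs from compound 3 in one place: (pentan-3-yl)oxy in place of isobutyl on a carbonyl carbon. Within the data shown here, no two measured compounds differ in only one place, so no measured step guides the expectation. All three numbers sit close together. In this assay the expected step is a number 3 percentage points lower from compound 3 to compound 4 (within the scatter), which would stay within the scatter in either direction. Compound 4 is therefore estimated at 40%, with a range from 25% to 55%.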

Compound 4, a percentage reported as inhibition, at one concentration (the size of the read-out at that concentration, not a potency): 6%
The estimate for compound 4 lay 34 percentage points above the measured number; measured number below the stated range.
By their numbers in this assay, from the lowest: compound 4; then compounds 2, 1 and 3 (each within the scatter of the next).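

In this assay, among these compounds, (pentan-3-yl)oxy in place of isobutyl on a carbonyl carbon gives a number 37 percentage points lower from compound 3 to compound 4 (beyond the scatter) and is the only step here that lies beyond the scatter. This shows that the number can depend strongly on the group at this carbonyl carbon, which the earlier values alone did not reveal. No available measurement accounts for this result. The compounds shown leave open whether the step follows the oxygen or the pentan-3-yl chain. An ethoxy group or a pentan-3-yl group attached directly to this carbonyl carbon would help separate the two.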